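Replacing the acyl ester of compound 1 with a glycolamide ester

The source may report more compounds than this note shows. Statements on the series, on what has been measured and on what is new or still open speak of the compounds shown alone.

Measured so far in rat liver microsomes:
- compound 1, `CCOc1cc(NC(=O)C2(NC(=O)c3ccc4c(C5CCCC5)c(-c5ncc(Cl)cn5)n(C)c4c3)CCC2)ccc1/C=C/C(=O)OC(=O)C[C@H](O)C(=O)O`, gives 7.92 h in an ADME assay (liver) for pharmacokinetics, with Liver microsome (Rattus norvegicus) as the target, using microsomes; on this read-out higher numbers stand for a longer-lived compound and lower numbers for a shorter-lived compound
- compound 2, `CCOc1cc(NC(=O)C2(NC(=O)c3ccc4c(C5CCCC5)c(-c5ncc(Cl)cn5)n(C)c4c3)CCC2)ccc1/C=C/C(=O)OCC(C)C`, gives 1.42 h in this assay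

Among the measured compounds shown here, compound 1 stands highest of the two numbers; the only neighbour is compound 2, which lies a 5.6-fold lower number from compound 1 to compound 2 (0.75 log units; beyond the scatter), a modest step beyond the scatter. That step put isobutyl in place of (2-carboxy-2-hydroxyethyl)carbonyl on an oxygen next to a carbonyl group.

Compound 3, `CCCN(C)C(=O)COC(=O)/C=C/c1ccc(NC(=O)C2(NC(=O)c3ccc4c(C5CCCC5)c(-c5ncc(Cl)cn5)n(C)c4c3)CCC2)cc1OCC`, has not yet been measured. It differs from compound 1 in one place: (methyl(propyl)carbamoyl)methyl in place of (2-carboxy-2-hydroxyethyl)carbonyl on an oxygen next to a carbonyl group. For the measured compounds named here, only one measured step bears on this change, the one from compound 1 to compound 2, which also took the (2-carboxy-2-hydroxyethyl)carbonyl away from that oxygen and put a chain without a carbonyl in its place; the number fell by a 5.6-fold lower number from compound 1 to compound 2 (0.75 log units; beyond the scatter). With nothing else to go on, a fall of about the same size is expected for compound 3, namely a 4.0-fold lower number from compound 1 to compound 3 (0.60 log units; beyond the scatter). Compound 3 is therefore estimated at 2 h, with a range from 0.8 h to 5 h.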

Compound 3, half-life: 0.317 h
Compound 3: middle estimate off by 6.3-fold (0.80 log units), on the high side; the measured number lies below the stated range.
By their numbers in this assay, from the lowest: compound 3; then compound 2; then compound 1.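

In this assay, among the compounds shown here, the group on this oxygen next to a carbonyl group counts for more than the first pair of compounds could show: (methyl(propyl)carbamoyl)methyl in place of (2-carboxy-2-hydroxyethyl)carbonyl gives a 25-fold lower number from compound 1 to compound 3 (1.40 log units; beyond the scatter), and this comes with no change in the count of 8 heavy atoms. Losing the (2-carboxy-2-hydroxyethyl)carbonyl group therefore does not fix the number alone, since compound 2 and compound 3 both lack it and still differ, with methyl(propyl)carbamoyl in place of isopropyl giving a 4.5-fold lower number from compound 2 to compound 3 (0.65 log units; beyond the scatter). Nothing measured here explains why these replacements shift the number.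

Compound 1 differs from compound 2 and compound 3 in its carboxylic acid, its hydroxyl and its carbonyl on the oxygen all at once, so the shown compounds do not tell which of these parts goes with its higher number. From the compounds shown here alone, it also stays open whether an amine in the chain, or a dimethyl amide in place of the methyl(propyl) amide, would fall nearer compound 3 or nearer compound 2.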